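A Naphthol Variant on the Hydrazone Carbon

The compounds below may be only part of what the source reports. "The series", "measured", "known", "first", "only" and "open" are said of these compounds alone.

Going by the values given here, compound 3 `CCCSc1nc(N/N=C/c2ccc(N(C)C)cc2)c2nnn(Cc3ccccc3)c2n1` gives 13100 nM in a functional assay on MGC-803 cells (Homo sapiens) for antiproliferative activity, read by MTT assay, with a stated time of 72 h (a lower number here means a stronger inhibitor, a higher number a weaker inhibitor), and stands lowest of the two numbers known. Compound 2 `CCCSc1nc(N/N=C/c2cccnc2)c2nnn(Cc3ccccc3)c2n1` gives 38100 nM in this assay, and the step of a 2.9-fold lower number from compound 2 to compound 3 (0.46 log units; beyond the scatter) lies beyond the usual scatter. Compound 1 `CCCSc1nc(N/N=C/c2ccc(C)cc2)c2nnn(Cc3ccccc3)c2n1` is reported in this assay only as a limit, > 64000 nM. From compound 1 the steps run an at least 1.6-fold lower number from compound 1 to compound 2 (0.22 log units; that floor lies within the scatter) and an at least 4.8-fold lower number from compound 1 to compound 3 (0.68 log units; beyond the scatter), the second at least modest, both resting on (the limit of > 64000 nM in this assay, at which 1 of the 3 values shown sits).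

Compound 4 `CCCSc1nc(N/N=C/c2c(O)ccc3ccccc23)c2nnn(Cc3ccccc3)c2n1` differs from compound 3 in one place: 2-hydroxynaphthalen-1-yl in place of 4-(dimethylamino)phenyl on a carbon with a double bond to nitrogen. Among the compounds with values here, none of the measured steps exchanges the group on the carbon with a double bond to nitrogen for a fused two-ring system carrying a hydroxy group, so the measured steps bear on compound 4 only as a pattern: each change of that group, from compound 1 through compound 2 to compound 3, moved the number by a modest amount at most. The expectation for compound 4 is therefore a step of similar modest size, most likely toward a higher number, as a 1.9-fold higher number from compound 3 to compound 4 (0.28 log units; within the scatter). Compound 4 is estimated at 25000 nM, with a range from 6000 nM to 64000 nM.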

Compound 4, half-maximal inhibitory concentration: 3710 nM
Estimate against measurement, compound 4: 6.7-fold (0.83 log units) above, and the stated range ends above it.
By their numbers in this assay, from the lowest: compound 4; then compound 3; then compound 2. At a limit, above all of these: compound 1.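

Going by these compounds alone, on the carbon with a double bond to nitrogen, the group can move the number further than the earlier compounds showed: in this assay, 2-hydroxynaphthalen-1-yl in place of 4-(dimethylamino)phenyl gives a 3.5-fold lower number from compound 3 to compound 4 (0.55 log units; beyond the scatter), which makes compound 4 the strongest inhibitor of the four. Set against the pyridin-3-yl group, the same entering group gives a 10-fold lower number from compound 2 to compound 4 (1.01 log units; beyond the scatter), a large step, whereas the one earlier exchange at this place between two exact numbers, a 2.9-fold lower number from compound 2 to compound 3 (0.46 log units; beyond the scatter), was modest. Set against the 4-methylphenyl group, it gives an at least 17-fold lower number from compound 1 to compound 4 (1.23 log units; beyond the scatter), a size that is only a floor since compound 1 is reported as a limit: the limit of > 64000 nM in this assay, at which 1 of the 4 values shown sits.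

Compound 4 brings in a second aromatic ring and a hydroxy group in one change, so the compounds shown do not tell which of the two goes with the lower number. From the compounds shown here alone, a plain naphthyl group or a hydroxyphenyl group on the same carbon would separate the two, and what a methoxy group in place of the hydroxy group would do also stays open.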